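The compounds below may be only part of what the source reports. "The series", "measured", "known", "first", "only" and "open" are said of these compounds alone.

Compound 1, `Cc1n[nH]c2ccc(-c3nc4cnc(N5CCN(C)CC5)cn4c3Nc3cccc(F)c3)cc12`, gives 18.5% in a functional assay on MV4-11 cells (Homo sapiens) for inhibition, with a stated time of 120 h, tested at 10 uM; a higher number here means more inhibition at the concentration tested (going by the name of the read-out), a lower number less inhibition.
Compound 2, `Cc1n[nH]c2ccc(-c3nc4cnc(N5CCN(C)CC5)cn4c3Nc3ccc(F)cc3)cc12`, gives 0%.
Compound 3, `Cc1n[nH]c2ccc(-c3nc4cnc(N5CCN(C)CC5)cn4c3Nc3ccccc3Cl)cc12`, gives 58.1%.

All three share one core and differ only in the group on a nitrogen on an aromatic ring. Compound 3, with its 2-chlorophenyl, has the highest number of the three: the rise a number 39.6 percentage points higher from compound 1 to compound 3 (beyond the scatter) and the rise a number 58.1 percentage points higher from compound 2 to compound 3 (beyond the scatter) both lie beyond the scatter. Compound 4, `COc1ccc(Nc2c(-c3ccc4[nH]nc(C)c4c3)nc3cnc(N4CCN(C)CC4)cn23)cc1`, has not yet been measured; it differs from compound 3 as 4-methoxyphenyl in place of 2-chlorophenyl on a nitrogen on an aromatic ring.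

Among the compounds with values here, two measured steps bear on this. The change a number 18.5 percentage points lower from compound 1 to compound 2 (beyond the scatter) shows that a 4-fluorophenyl, which like 4-methoxyphenyl carries its substituent at the 4-position, gave the lowest number of the set. The change a number 58.1 percentage points higher from compound 2 to compound 3 (beyond the scatter) shows how far the 2-chlorophenyl of compound 3 stands above that 4-fluorophenyl. Compound 4 therefore is expected to fall well below compound 3, by an estimated a number 52.1 percentage points lower from compound 3 to compound 4 (beyond the scatter), a drop beyond the scatter. Compound 4 is estimated at 6%, within a range from 0% to 25%.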

Compound 4, a percentage reported as inhibition, at one concentration (the size of the read-out at that concentration, not a potency): 3.32%
Compound 4: middle estimate off by 2.7 percentage points, on the high side, and the stated range covers the measured number.
By their numbers in this assay, from the lowest: compounds 2 and 4 (each within the scatter of the next); then compound 1; then compound 3.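

In this assay, methoxy in place of fluoro on an aromatic carbon gives a number 3.3 percentage points higher from compound 2 to compound 4 (within the scatter), so the 4-methoxyphenyl and the 4-fluorophenyl cannot be told apart here. The 4-methoxyphenyl also falls short of both other groups on this nitrogen, with a number 54.8 percentage points lower from compound 3 to compound 4 (beyond the scatter) and a number 15.2 percentage points lower from compound 1 to compound 4 (beyond the scatter), so the two compounds with low numbers now carry different groups, while the 3-fluorophenyl of compound 1 and the 2-chlorophenyl of compound 3 give higher numbers. No measured data on hand explain why these groups differ in this way.

The compounds shown leave open whether the high number of compound 3 goes with the chlorine itself or with where it sits on the ring. A 2-fluorophenyl, a 4-chlorophenyl or a 2-methoxyphenyl on the same nitrogen would help separate these two readings.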